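A few compounds are considered here, and "the series" means these few. Any claim that something is new, unique, unknown or untested is made for them only; others in the source may bear on it.

Working notes on the series, read in a toxicity assay on MT4 cells (Homo sapiens) for cytotoxicity, read by MTT assay; a higher number here means that more compound is tolerated, a lower number that less compound is tolerated. Compound 1 `Cc1cc(-c2cccc(F)c2)cc(C)c1Oc1cc(N)nc(Nc2ccc(C#N)cc2)n1` gives 24700 nM, and compound 2 `Cc1cc(-c2ccccc2Cl)cc(C)c1Oc1cc(N)nc(Nc2ccc(C#N)cc2)n1` gives 25100 nM. For the measured compounds named here, compound 2 therefore stands level with compound 1, the only other number so far, within the scatter. The next structure is compound 3 `Cc1cccc(-c2cc(C)c(Oc3cc(N)nc(Nc4ccc(C#N)cc4)n3)c(C)c2)c1`, which has 3-methylphenyl in place of 2-chlorophenyl on an aromatic carbon, meta to two methyl groups and para to a large group: 3-methylphenyl in place of 2-chlorophenyl on an aromatic carbon. Going by the values given here, the one measured step that bears on this change is a 1.0-fold higher number from compound 1 to compound 2 (0.01 log units; within the scatter), which also exchanges one substituted phenyl for another on an aromatic carbon. Among the compounds with values here, that is thin evidence, and no measured compound carries 3-methylphenyl. No shift beyond the scatter is expected in this assay. The estimated change is a 1.0-fold lower number from compound 2 to compound 3 (0.02 log units; within the scatter). The expected value for compound 3 is 24000 nM, with an estimated range of 11000 nM to 50000 nM.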

Compound 3, half-maximal cytotoxic concentration: 27600 nM
Compound 3: the middle estimate sits 1.2-fold (0.06 log units) below what was measured; the range from low to high includes it.
By their numbers in this assay, from the lowest: compounds 1, 2 and 3 (each within the scatter of the next).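

In this assay, the change to 3-methylphenyl gives a 1.1-fold higher number from compound 2 to compound 3 (0.04 log units; within the scatter), so a third substituted phenyl at this position, meta to two methyl groups and para to a large group, also stays level with the others. The change of methyl in place of fluoro on the phenyl gives a 1.1-fold higher number from compound 1 to compound 3 (0.05 log units; within the scatter), which adds a direct comparison of two groups on that ring and again shows no separation. Nothing measured here offers an account of these readings.

On these data alone, all three compounds carry a substituted phenyl at this position, so it remains open whether a carboxylic acid or an aminomethyl group on that phenyl would stay level in this assay. As far as these compounds go, replacing the phenyl with a morpholine ring or a longer alkyl chain is equally open.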